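Swapping one group on a sulfonamide nitrogen

This account rests on a few compounds, and the source may have more. Where it says the series, first, only, none or still open, it means among the compounds named here.

Compound 1 `O=S(=O)(c1ccc2c(c1)C(O)CC(C1CCOCC1)O2)N1CCC(c2ccccc2)CC1` gives 2.63
Compound 2 `CC(C)CN(c1cc2ccccc2s1)S(=O)(=O)c1ccc2c(c1)C(O)CC(C1CCOCC1)O2` gives 3.92
Compound 3 `CCc1ccc(N(CC(C)C)S(=O)(=O)c2ccc3c(c2)C(O)C[C@@H](C2CCOCC2)O3)cc1` gives 4.12

Among the measured compounds shown here, all three numbers come from a physicochemical assay for lipophilicity, at pH 7.4 (a lower number here means a more polar compound, a higher number a more lipophilic compound), and are the only measurements so far. Compound 2 (3.92) lies within the scatter of compound 3 (4.12), while compound 1 (2.63) lies lower, beyond the scatter.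

Compound 4 `Cc1ccc(N(CC(C)C)S(=O)(=O)c2ccc3c(c2)C(O)CC(C2CCOCC2)O3)c(C)c1` has not been measured. It differs from compound 2 in one place, with 2,4-dimethylphenyl in place of 1-benzothiophen-2-yl on a sulfonamide nitrogen.

For the measured compounds named here, no two measured compounds differ in only one place, so no measured step shows what this swap does. The nearest guide is compound 3 (4.12), which also has an alkyl-bearing phenyl group on a sulfonamide nitrogen. No step beyond the scatter is therefore expected in this assay, and the estimated size and direction are given by a number 0.13 log units higher from compound 2 to compound 4 (within the scatter) (a slight rise). For compound 4 the estimated value is 4.05 (expected range 3.65 to 4.45).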

Compound 4, distribution coefficient: 4.19
For compound 4 the middle estimate is 0.14 log units below the measured one; the measured number falls inside the stated range.
By their numbers in this assay, from the lowest: compound 1; then compounds 2, 3 and 4 (each within the scatter of the next).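

Among the compounds shown here, this is the first single-place step at this position: in this assay, 2,4-dimethylphenyl in place of 1-benzothiophen-2-yl on a sulfonamide nitrogen gives a number 0.27 log units higher from compound 2 to compound 4 (within the scatter). On this nitrogen, whose other neighbours are a saturated chain carbon and the sulfonyl sulfur, this read-out therefore cannot separate the two-ring, sulfur-containing group from the single carbon-only ring carrying two methyl groups. No measurement at hand offers a reason for this result.

The compounds shown leave open whether a different kind of group on this nitrogen, such as an amine or a carboxylic acid, would give a step beyond the scatter. They also do not show what a longer chain would do in place of the saturated chain on the same nitrogen.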